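A few compounds are considered here, and "the series" means these few. Any claim that something is new, unique, unknown or untested is made for them only; others in the source may bear on it.

In an ADME assay on L6 cells (Rattus norvegicus) for cytotoxicity, read by resazurin assay, with a stated time of 72 h (on this read-out lower numbers stand for stronger inhibition and higher numbers for weaker inhibition), compound 1 (`N=C(N)c1cccc(OCc2ccccc2)c1`) gives 156000000 nM, while compound 2 (`N=C(N)c1ccc(COc2cccc([N+](=O)[O-])c2)cc1`) gives 57800000 nM. Compound 2 therefore holds the lower of the two numbers, with a gap to compound 1 that lies beyond the scatter. Compound 3 (`N=C(N)c1ccc(COc2cccc(C(=N)N)c2)cc1`) differs from compound 2 in one place, on an aromatic carbon: a group of 3 heavy atoms (1 carbon, 2 nitrogen; no ring) in place of a group of 3 heavy atoms (1 nitrogen, 2 oxygen; no ring), on an aromatic carbon. Among the compounds with values here, no measured step shows what this change does, so no step beyond the scatter is expected in this assay, though with wide uncertainty. The expected change is a 1.2-fold lower number from compound 2 to compound 3 (0.06 log units; within the scatter). For compound 3 the estimated value is 50000000 nM, with an expected range from 10000000 nM to 200000000 nM.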

Compound 3, half-maximal inhibitory concentration: 19300000 nM
Estimate against measurement, compound 3: 2.6-fold (0.41 log units) above; low and high end bracket the measured number.
By their numbers in this assay, from the lowest: compound 3; then compound 2; then compound 1.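

In this assay, the group entering on this aromatic carbon, meta to a large group, replaces nitro with a 3.0-fold lower number from compound 2 to compound 3 (0.48 log units; beyond the scatter). Put in place of a hydrogen atom, the same group gives an 8.1-fold lower number from compound 1 to compound 3 (0.91 log units; beyond the scatter), so at this position it lowers the number against both of the groups it replaces. Nothing on hand accounts for either step. The compounds shown leave open whether an amine or a carboxylic acid on this carbon would also lower the number.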